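Amide substituents on the shared core: cyclobutyl next

This account rests on a few compounds, and the source may have more. Where it says the series, first, only, none or still open, it means among the compounds named here.

Measured compounds in an ADME assay on Vero cells (Chlorocebus sabaeus) for cytotoxicity, read by MTT assay, with a stated time of 72 h; a higher number here means that more compound is tolerated, a lower number that less compound is tolerated:
- compound 1 `CCCCC(=O)N1CCN(c2nc(=O)c3cc(C(F)(F)F)cc([N+](=O)[O-])c3s2)CC1` gives > 125000 nM, a limit of the assay.
- compound 2 `CCC(C)C(=O)N1CCN(c2nc(=O)c3cc(C(F)(F)F)cc([N+](=O)[O-])c3s2)CC1` gives > 125000 nM, also a limit of the assay.
- compound 3 `O=C(C1CCCC1)N1CCN(c2nc(=O)c3cc(C(F)(F)F)cc([N+](=O)[O-])c3s2)CC1` gives 120000 nM.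

Within the data shown here, compound 3 stands as the only actual number in this assay; the other two values are limits, as the limit of > 125000 nM in this assay, at which 2 of the 3 values shown sit, records. The steps toward compound 3 are an at least 1.0-fold lower number from compound 1 to compound 3 (0.01 log units; that floor lies within the scatter) and an at least 1.0-fold lower number from compound 2 to compound 3 (0.01 log units; that floor lies within the scatter), both resting on a limit and lying within the scatter, so the three amides show no separation on the numbers available.

Compound 4 `O=C(C1CCC1)N1CCN(c2nc(=O)c3cc(C(F)(F)F)cc([N+](=O)[O-])c3s2)CC1` carries the change (cyclobutyl in place of cyclopentyl on a carbonyl carbon). Among the measured compounds shown here, no measured step covers a cyclobutyl, but the measured steps to compound 3 from the butyl, sec-butyl and cyclopentyl amides show no movement beyond the scatter, and a small ring change on the same carbonyl carbon is expected to behave alike. The expected step is no change at the digits printed from compound 3 to compound 4 (within the scatter), with a fair chance that only a limit is reported again.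

Compound 4 is therefore estimated at 120000 nM, with a range from 60000 nM to 250000 nM.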

Compound 4, half-maximal cytotoxic concentration: > 125000 nM
Compound 4: a limit, no number (the forecaster's own chance of this, stated with the estimate: 50%); at least 1.0-fold (0.01 log units) between middle value and limit.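

In this assay the change from cyclopentyl to cyclobutyl on the carbonyl carbon gives an at least 1.0-fold higher number from compound 3 to compound 4 (0.01 log units; that floor lies within the scatter) and so separates neither amide from the other on the numbers available. Compound 4 reports only a limit, so a four-membered ring here joins the butyl and sec-butyl amides of compound 1 and compound 2 without yielding a new number, and the steps from those two compounds to compound 4 cannot be read. The position now reads mostly as limits: the limit of > 125000 nM in this assay, at which 3 of the 4 values shown sit.

From the compounds shown here alone, whether an aminomethyl group, a carboxylic acid or a longer chain on this carbonyl carbon would give a number clearly apart from compound 3 stays open. Going by these compounds, with one actual number among the four amides, any order among them also stays open.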